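The source may report more compounds than this note shows. Statements on the series, on what has been measured and on what is new or still open speak of the compounds shown alone.

Measured compounds:
- compound 1, `CCCCCCCCCCCCc1ccccc1C(SCCC(=O)O)SCCC(=O)O`: 445 nM
- compound 2, `CCCCCCCCCCCCCCc1ccccc1C(SCCC(=O)O)SCCC(=O)O`: 1250 nM
- compound 3, `CCCCCCCCCCCOc1ccccc1C(SCCC(=O)O)SCCC(=O)O`: 287 nM

All three were tested in an assay on membranes from lung (Cavia porcellus) for binding affinity to cysteinyl leukotriene receptor (Homo sapiens); a higher number here means a weaker inhibitor, a lower number a stronger inhibitor. Compound 2 carries the longest chain on the shared core and gives the highest number of the three. Going from compound 2 to compound 1 the chain is cut short, (hydrogen in place of ethyl on a saturated chain carbon, ten or more bonds along the chain from an aromatic carbon), and the number falls: a 2.8-fold lower number from compound 2 to compound 1 (0.45 log units; beyond the scatter). Compound 3 has a different core from compound 2; the difference between the two cores is not broken down here. Compound 3 gives the lowest number of the three, though its gap to compound 1 is within the usual scatter, so no order between compound 3 and compound 1 can be read from these values.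

Compound 4, `CCCCCCCCCOc1ccccc1C(SCCC(=O)O)SCCC(=O)O`, has not yet been measured. It is made from compound 3 by the same kind of change that turns compound 2 into compound 1, (hydrogen in place of ethyl on a saturated chain carbon, nine bonds along the chain from an oxygen on an aromatic ring), but the place differs: in compound 3 the chain hangs from an oxygen on an aromatic ring, whereas in compound 2 the chain hangs from an aromatic carbon. Because the earlier cut gave a 2.8-fold lower number from compound 2 to compound 1 (0.45 log units; beyond the scatter), a step of similar direction is expected for compound 4, though a smaller one is estimated, since compound 3 already gives 287 nM and the shorter chain need not keep helping. The expected step is a 1.3-fold lower number from compound 3 to compound 4 (0.12 log units; within the scatter). For compound 4 the estimate in this assay is 220 nM, with a likely range from 80 nM to 600 nM.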

Compound 4, inhibition constant: 4090 nM
Beside the measured number, compound 4's estimate is 19-fold (1.27 log units) below it; the measured number lies above the stated range.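

In this assay, the same cut at the end of the chain has opposite effects on the two cores: on the core of compound 3 it gives a 14-fold higher number from compound 3 to compound 4 (1.15 log units; beyond the scatter), whereas the earlier cut on the core of compound 2 lowered the number. Set side by side, the two steps differ by more than repeated measurements would explain, which shows that the result of this change depends on the core that carries it: the same change on two cores in this assay, a 2.8-fold lower number (0.45 log units; beyond the scatter) from compound 2 to compound 1 and a 14-fold higher number (1.15 log units; beyond the scatter) from compound 3 to compound 4, 40-fold (1.60 log units) apart, beyond the scatter of two such steps A step measured on one of these cores therefore cannot simply be carried over to the other, but the comparison does not show why the two cores differ, and with only two pairs of compounds it sets no rule for other chains or other cores in the series.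

Among the compounds shown here, each core appears here with only two chain lengths, so it remains open whether the number changes gradually along the chain or abruptly at one particular length. Also open, on these data alone, are how a longer chain on the core of compound 3 would behave, and what a chain ending in an amine or a carboxylic acid would do on either core.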